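A few compounds are considered here, and "the series" means these few. Any claim that something is new, unique, unknown or untested is made for them only; others in the source may bear on it.

Measured so far: compound 1 `CC(=O)OCCSC[C@H]1CN(C)CC[C@H]1c1ccc(Cl)cc1` with 610 nM in an assay on a subcellular fraction from brain with Norepinephrine transporter (Rattus norvegicus) as the target (a higher number here means a weaker inhibitor, a lower number a stronger inhibitor), and compound 2 `CC(=O)OCCSC[C@@H]1CN(C)CC[C@H]1c1ccc(Cl)cc1` with 52 nM.

Compound 1 stands with the higher of the two numbers; its nearest neighbour is compound 2, and the step of a 12-fold lower number from compound 1 to compound 2 (1.07 log units; beyond the scatter) is large. That step rests on a single change of configuration, because the fact that compounds 1 and 2 differ only in the configuration as drawn is all that separates the two compounds.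

Compound 3 `CC(=O)OCCSC[C@@H]1CN(C)CC[C@@H]1c1ccc(Cl)cc1` is the next compound to be measured. Against compound 1 the change is the two compounds have the same atoms and bonds and differ only in configuration as drawn: 2 of 2 stereo elements differ (all stereocentres are inverted: mirror images); a stereocentre at a saturated ring carbon is drawn R in compound 1 and S in compound 3; a stereocentre at a saturated ring carbon is drawn R in compound 1 and S in compound 3: the two compounds are mirror images, with both stereocentres at saturated ring carbons inverted. Going by the values given here, the only measured step that bears on this is the one from compound 1 to compound 2, where inverting one of the two centres already moved the number far beyond the scatter. That makes it likely that inverting both will also move the number beyond the scatter, but the measured data give no direction for a mirror-image pair. Compound 3 is therefore expected to differ from compound 1 by a step of about a 1.5-fold lower number from compound 1 to compound 3 (0.18 log units; within the scatter), with the direction open. For compound 3 the estimated value in this assay is 400 nM, within a wide range from 60 nM to 3000 nM.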

Compound 3, inhibition constant: 30 nM
Estimate against measurement, compound 3: 13-fold (1.12 log units) above; the whole stated range lies above it.
By their numbers in this assay, from the lowest: compounds 3 and 2 (each within the scatter of the next); then compound 1.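

The mirror-image pair is not equal in this assay: the result is a 20-fold lower number from compound 1 to compound 3 (1.31 log units; beyond the scatter), so this read-out clearly separates the two mirror-image forms. Inverting the remaining centre alone gives a 1.7-fold lower number from compound 2 to compound 3 (0.24 log units; within the scatter), so once the first centre is drawn as in compound 2, the configuration of the second does not register beyond the scatter, unlike the single inversion in a 12-fold lower number from compound 1 to compound 2 (1.07 log units; beyond the scatter). Configuration is the only thing that can stand behind the large gap between the mirror images: the fact that compounds 1 and 3 differ only in the configuration as drawn

The fourth combination of the two centres, the mirror image of compound 2, is absent from the compounds shown, so it remains open whether the second centre counts when the first is drawn as in compound 1. From the compounds shown here alone, it is also open whether the same dependence on configuration would hold if the shared core carried a carboxylic acid, an amide or a longer chain in place of the acetyl ester, or how these configurations would read on any target other than this one.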